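From fluoromethyl to difluoromethyl: a small step expected

The compounds below may be only part of what the source reports. "The series", "measured", "known", "first", "only" and "open" are said of these compounds alone.

Values in a physicochemical assay for lipophilicity, read by HPLC, in phosphate buffer, measured as octanol-water partition, with a stated time of 1 h, at pH 7.4; on this read-out lower numbers stand for lower lipophilicity and higher numbers for higher lipophilicity:
- compound 1 `Cc1cc(C#N)cnc1C(=O)Nc1ccc(F)c([C@]2(C)C=C(CF)OC(N)=N2)c1` gives 2.5
- compound 2 `COc1cnc(C(=O)Nc2ccc(F)c([C@]3(C)C=C(CF)OC(N)=N3)c2)cn1` gives 2.7
- compound 3 `C[C@@]1(c2cc(NC(=O)c3coc(CF)n3)ccc2F)C=C(CF)OC(N)=N1` gives 2.2

Compound 1 is not clearly separated from either of the other two compounds. The two steps that start from it are a number 0.20 log units higher from compound 1 to compound 2 (within the scatter) and a number 0.30 log units lower from compound 1 to compound 3 (within the scatter), and neither clears the usual scatter.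

Compound 4 `Cc1cc(C#N)cnc1C(=O)Nc1ccc(F)c([C@]2(C)C=C(C(F)F)OC(N)=N2)c1` differs from compound 1 in one place (fluoro in place of hydrogen on a saturated chain carbon bound to a double-bonded ring carbon and a fluorine atom). It carries fluoro in place of hydrogen on a saturated chain carbon bound to a double-bonded ring carbon and a fluorine atom, so fluoromethyl becomes difluoromethyl.

Going by the values given here, none of the measured steps touches that group. All three swap the group on a carbonyl carbon, so they indicate only the size of step this series can show. Among the compounds with values here, the largest is a number 0.50 log units lower from compound 2 to compound 3 (beyond the scatter), and it replaces a whole group, a bigger edit than the one in compound 4. Within the data shown here, no measured pair shows the fluoromethyl change itself, so the upward direction is a judgement from the structural change alone.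

The expected change is a number 0.20 log units higher from compound 1 to compound 4 (within the scatter), a small rise that may not clear the scatter. For compound 4 the estimated value in this assay is 2.7, with an expected range from 2.4 to 3.1.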

Compound 4, distribution coefficient: 2.9
The estimate for compound 4 lay 0.20 log units below the measured number; low and high end bracket the measured number.
By their numbers in this assay, from the lowest: compounds 3, 1, 2 and 4 (each within the scatter of the next, the first and the last beyond it).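

Until now, every measured step changed the group on a carbonyl carbon, so nothing showed whether the fluoromethyl end of the core matters on this read-out. In this assay, fluoromethyl becoming difluoromethyl gives a number 0.40 log units higher from compound 1 to compound 4 (beyond the scatter), so this position does register, and the added fluorine atom alone is enough to clear the usual scatter. That puts this small edit with the whole-group replacement that gives a number 0.50 log units lower from compound 2 to compound 3 (beyond the scatter), and apart from the two whole-group replacements starting at compound 1, neither of which cleared the scatter. Nothing measured here explains why the number moves at this position.

Going by these compounds alone, the same edit is seen only with the 5-cyano-3-methylpyridin-2-yl group on the carbonyl carbon, so it remains open whether it gives a similar step alongside the 5-methoxypyrazin-2-yl or 2-(fluoromethyl)-1,3-oxazol-4-yl group. Going by these compounds, it also remains open whether the number keeps following the fluorine count once this carbon carries a trifluoromethyl group, or what a plain methyl group or a longer chain such as ethyl would read there.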